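A few compounds are considered here, and "the series" means these few. Any claim that something is new, unique, unknown or untested is made for them only; others in the source may bear on it.

Compound 1 `COC(=O)/C=C/c1cccc(N(Cc2ccc(/C=C/c3ccccn3)cc2)C(=O)C2CCCCC2)c1` gives 309 nM in an assay on isolated protein with Bile acid receptor (Homo sapiens) as the target; on this read-out lower numbers stand for an effect already at smaller amounts and higher numbers for an effect only at larger amounts of compound.
Compound 2 `COC(=O)/C=C/c1cccc(N(Cc2ccc(/C=C/c3ccccn3)cc2)C(=O)C(C)C)c1` gives 310 nM in this assay.
For compound 3 `COC(=O)/C=C/c1cccc(N(Cc2ccc(/C=C/C(=O)O)cc2)C(=O)C2CCCCC2)c1` this assay reports only a limit, > 1000 nM.

Compound 2 thus stands beside compound 1 among the two numbers shown, since the step of a 1.0-fold higher number from compound 1 to compound 2 (0.00 log units; within the scatter) is within the scatter, and the remaining value is a limit. The step of an at least 3.2-fold higher number from compound 1 to compound 3 (0.51 log units; beyond the scatter) runs into that limit (the limit of > 1000 nM in this assay, at which 1 of the 3 values shown sits).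

Compound 4 `COC(=O)/C=C/c1cccc(N(Cc2ccc(/C=C/c3ccccc3)cc2)C(=O)C(C)C)c1` differs from compound 2 by phenyl in place of pyridin-2-yl on a double-bonded chain carbon bound to a double-bonded chain carbon. Among the measured compounds shown here, only one measured step touches the same place: from compound 1 to compound 3, where carboxy enters instead, and it gives an at least 3.2-fold higher number from compound 1 to compound 3 (0.51 log units; beyond the scatter). Phenyl is not carboxy, and the measured step shows only that a change at this place can cost at least modestly; the step from compound 1 to compound 2 shows that the other end of the molecule tolerates change within the scatter. A modest loss, or none beyond the scatter, is expected. Compound 4 is estimated at 450 nM in this assay, with a range from 150 nM to 1400 nM, which is expected to mean a step of a 1.5-fold higher number from compound 2 to compound 4 (0.16 log units; within the scatter).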

Compound 4, half-maximal effective concentration: 65 nM
For compound 4 the middle estimate is 6.9-fold (0.84 log units) above the measured one, outside the stated range (below it).
By their numbers in this assay, from the lowest: compound 4; then compounds 1 and 2 (each within the scatter of the next). At a limit, above all of these: compound 3.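

At this place the earlier compounds had shown only a loss, with carboxy in compound 3, whose value is a limit. Phenyl in place of pyridin-2-yl now gives a 4.8-fold lower number from compound 2 to compound 4 (0.68 log units; beyond the scatter) and so shows that the same place can also move the number down. This comes from a small change, since both groups have the same count of heavy atoms and a ring nitrogen gives way to carbon, but nothing shown here accounts for the gain.

Phenyl appears here only with isopropyl on the carbonyl carbon, so whether it gives a similar step with cyclohexyl there stays open. Also open, going by these compounds, is how a pyridin-3-yl ring, or a phenyl carrying an amine or a methoxy group, would compare with phenyl at this place.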